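This account rests on a few compounds, and the source may have more. Where it says the series, first, only, none or still open, it means among the compounds named here.

Measured compounds in a functional assay on MCF7 cells (Homo sapiens) for antiproliferative activity; a higher number here means a weaker inhibitor, a lower number a stronger inhibitor:
compound 1 `CCCn1c(Cc2cc(OC)c(OC)c(OC)c2)nc2c(N)ncnc21`, 46800 nM
compound 2 `COc1cc(Cc2nc3c(N)ncnc3n2CCCC(C)C)cc(OC)c1OC`, 69200 nM
compound 3 `CCCn1c(Cc2cc(OC)c(OC)c(OC)c2)nc2c(N)nc(F)nc21`, 25100 nM

Compound 3 gives the lowest of these three numbers; its nearest neighbour is compound 1, reached by the step of a 1.9-fold lower number from compound 1 to compound 3 (0.27 log units; within the scatter), while compound 2 stands furthest away, beyond the scatter.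

Compound 4 `COCCn1c(Cc2cc(OC)c(OC)c(OC)c2)nc2c(N)nc(F)nc21` differs from compound 3 in one place: methoxy in place of methyl on a saturated chain carbon, two bonds along the chain from an aromatic nitrogen. Among the measured compounds shown here, only one measured step touches this chain, a 1.5-fold higher number from compound 1 to compound 2 (0.17 log units; within the scatter), and it changed a different spot on the chain without moving the number beyond the scatter. For the measured compounds named here, no measured step tells what a methoxy at this place does, so no change beyond the scatter is expected. Compound 4 is therefore estimated at 25000 nM, ranging from 10000 nM to 63000 nM, an expected step of a 1.0-fold lower number from compound 3 to compound 4 (0.00 log units; within the scatter).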

Compound 4, half-maximal inhibitory concentration: 64600 nM
Beside the measured number, compound 4's estimate is 2.6-fold (0.41 log units) below it, and the stated range ends below it.
By their numbers in this assay, from the lowest: compounds 3, 1, 4 and 2 (each within the scatter of the next, the first and the last beyond it).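

In this assay, replacing the propyl chain with 2-methoxyethyl gives a weaker inhibitor (a 2.6-fold higher number from compound 3 to compound 4 (0.41 log units; beyond the scatter)). Among the compounds shown here, this is the first change on this chain to move the number beyond the scatter, as the isopropyl step stayed within it (a 1.5-fold higher number from compound 1 to compound 2 (0.17 log units; within the scatter)), so this chain is not indifferent to every change made on it. No measured evidence explains this rise.

The compounds shown leave open whether a hydroxy group or an amine at this place would act like methoxy. They also leave open whether the step would hold without the fluoro group.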